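Swapping the sulfonate aryl group in a P2X7 antagonist series

This account rests on a few compounds, and the source may have more. Where it says the series, first, only, none or still open, it means among the compounds named here.

Compound 3 `O=C(c1ccc([N+](=O)[O-])cc1)N1CCC(n2cncc2-c2ccc(OS(=O)(=O)c3cccc4cnccc34)cc2)CC1` sits at the high end of the three numbers recorded in an assay on THP-1 cells for antagonist activity at P2X purinoceptor 7 (Homo sapiens), read by ELISA, with a stated time of 30 min (on this read-out higher numbers stand for weaker inhibition and lower numbers for stronger inhibition), where compound 3 gives 8.29 nM. Compound 1 `N#Cc1cccc(S(=O)(=O)Oc2ccc(-c3cncn3C3CCN(C(=O)c4ccc(Cl)c(C(F)(F)F)c4)CC3)cc2)c1` gives 4.28 nM in this assay, and compound 2 `CS(=O)(=O)c1ccc(C(=O)N2CCC(n3cncc3-c3ccc(OS(=O)(=O)c4cccc5cnccc45)cc3)CC2)cc1` gives 0.32 nM. For the measured compounds named here, the only single-point step among the measured compounds is a 26-fold higher number from compound 2 to compound 3 (1.41 log units; beyond the scatter), which concerns the amide aryl group rather than the sulfonate. Compound 4 `N#Cc1cccc(S(=O)(=O)Oc2ccc(-c3cncn3C3CCN(C(=O)c4ccc([N+](=O)[O-])cc4)CC3)cc2)c1` keeps the nitro amide of compound 3 but carries 3-cyanophenyl in place of isoquinolin-5-yl on a sulfonyl sulfur. Going by the values given here, no measured step isolates this exchange: compound 1 and compound 2 differ from each other in two places, so their values show only that both a 3-cyanophenyl sulfonate and an isoquinolin-5-yl sulfonate appear in potent members of this set. With compound 1 and compound 3 both in the same region of this assay, the sulfonate exchange is expected to give no change beyond the scatter, a 1.2-fold lower number from compound 3 to compound 4 (0.07 log units; within the scatter). Compound 4 is therefore estimated at 7 nM, within a range of 2 nM to 25 nM.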

Compound 4, half-maximal inhibitory concentration: 13 nM
The estimate for compound 4 lay 1.9-fold (0.27 log units) below the measured number, within the range that was stated.
By their numbers in this assay, from the lowest: compound 2; then compounds 1, 3 and 4 (each within the scatter of the next, the first and the last beyond it).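

With the nitro amide held fixed, the exchange of isoquinolin-5-yl for 3-cyanophenyl on a sulfonyl sulfur can now be read directly in this assay (a 1.6-fold higher number from compound 3 to compound 4 (0.20 log units; within the scatter)), and on this amide the two sulfonate groups cannot be told apart. With the 3-cyanophenyl sulfonate held fixed, the amide aryl group does register (a 3.0-fold higher number from compound 1 to compound 4 (0.48 log units; beyond the scatter)), which gives a second single-place step on the carbonyl carbon alongside the one already seen with the isoquinolin-5-yl sulfonate (a 26-fold higher number from compound 2 to compound 3 (1.41 log units; beyond the scatter)). No evidence at hand accounts for either new step.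

On these data alone, it remains open whether the sulfonate exchange would stay this small on the methylsulfonyl amide of compound 2. As far as these compounds go, how a sulfonate aryl group bearing an amine or a carboxylic acid in place of the nitrile would read in this assay also remains open.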